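Replacing Naphthalen-1-yl with 4-Chlorophenyl: One Step Ahead

A few compounds are considered here, and "the series" means these few. Any claim that something is new, unique, unknown or untested is made for them only; others in the source may bear on it.

Measured compounds and their values:
compound 1 `Cc1cc(-c2ccccc2)n(/C(N)=N/S(=O)(=O)c2cc(C)c(Cl)cc2SCc2cccc3ccccc23)n1`: 7000 nM
compound 2 `Cc1cc(-c2ccccc2)n(/C(N)=N/S(=O)(=O)c2cc(C)c(Cl)cc2SCc2ccc(C(F)(F)F)cc2)n1`: 7000 nM
compound 3 `Cc1cc(S(=O)(=O)/N=C(\N)n2nccc2-c2ccccc2)c(SCc2cccc3ccccc23)cc1Cl`: 7000 nM

All three values come from a functional assay on HCT-116 cells (Homo sapiens) for cytotoxicity, read by MTT assay, with a stated time of 72 h; a higher number here means a weaker inhibitor, a lower number a stronger inhibitor. Compound 3 stands level with compound 1 and compound 2 at the digits shown; the step of no change at the digits printed from compound 1 to compound 3 (within the scatter), where hydrogen replaced methyl on an aromatic carbon, and the step of no change at the digits printed from compound 1 to compound 2 (within the scatter) both lie within the scatter. There is no step or difference listed between compound 2 and compound 3, so only their two values, which agree, can be compared.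

Compound 4 `Cc1cc(S(=O)(=O)/N=C(\N)n2nccc2-c2ccccc2)c(SCc2ccc(Cl)cc2)cc1Cl` has not yet been measured. It differs from compound 3 in one place: 4-chlorophenyl in place of naphthalen-1-yl on a saturated chain carbon bound to a sulfur. Among the compounds with values here, the step that bears most directly on this is the one from compound 1 to compound 2, where a single six-membered aromatic ring carrying a trifluoromethyl group replaced naphthalen-1-yl at the same saturated chain carbon bound to a sulfur, and the value did not move beyond the scatter. On that basis, compound 4 is expected to show a step of no change at the digits printed from compound 3 to compound 4 (within the scatter) in this assay, that is, none beyond the scatter. Compound 4 is therefore estimated at 7000 nM, with a range from 3500 nM to 14000 nM.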

Compound 4, half-maximal inhibitory concentration: 7000 nM
Beside the measured number, compound 4's estimate shows no gap at the digits printed; the measured number falls inside the stated range.
By their numbers in this assay, from the lowest: compounds 1, 2, 3 and 4 (each within the scatter of the next).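

Putting 4-chlorophenyl in place of naphthalen-1-yl in this assay gives no change at the digits printed from compound 3 to compound 4 (within the scatter) and so shows that, on this saturated chain carbon bound to a sulfur, a group of 10 heavy atoms with two aromatic rings can give way to one of 7 heavy atoms with a single ring without moving the number. The earlier swap at this carbon was made on the core of compound 1, which carries the extra methyl, and brought in a ring bearing trifluoromethyl, whereas this one is made on the core of compound 3, which has hydrogen on that aromatic carbon, and brings in a ring bearing chlorine. Nothing measured here explains why the value holds steady through these changes.

Since all the groups shown at this carbon are aromatic rings held on the same single carbon, these compounds do not tell what a ring bearing an amine or a carboxylic acid would do to the value. They also leave open whether a longer chain between the sulfur and the ring, or a plain alkyl chain with no ring at all, would shift the number in this assay.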